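This account rests on a few compounds, and the source may have more. Where it says the series, first, only, none or still open, it means among the compounds named here.

Compound 1 `CCCC[S+]([O-])c1sc2nc(-c3nccs3)cc(-c3nccs3)c2c1N`: 1.8 nM
Compound 2 `CCCC[S+]([O-])c1sc2nc(-c3nccs3)cc(-c3ccc(CNC(=O)NCC)cc3)c2c1N`: 2.1 nM

In an assay for inhibition of 15-hydroxyprostaglandin dehydrogenase [NAD(+)] (Homo sapiens), read by fluorescence, with a stated time of 15 min, in the presence of a further agent that is not named here (on this read-out higher numbers stand for weaker inhibition and lower numbers for stronger inhibition), compound 2 gives 2.1 nM, a number that lies within the usual scatter of what compound 1 gives, 1.8 nM, so the two cannot be told apart. Compound 3 `CCCC[S+]([O-])c1sc2nc(-c3nccs3)cc(-c3ccc(CCO)cc3)c2c1N` differs from compound 2 by hydroxymethyl in place of (ethylcarbamoyl)amino on a saturated chain carbon bound to an aromatic carbon, a hydroxymethyl in place of the (ethylcarbamoyl)amino on a saturated chain carbon bound to an aromatic carbon. Because compound 1 gives 1.8 nM with a quite different group on the shared core, this part of the molecule seems to tolerate change, and the expected step of a 1.4-fold higher number from compound 2 to compound 3 (0.15 log units; within the scatter) is none beyond the scatter. Compound 3 is estimated at 3 nM, between 1.2 nM and 8 nM.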

Compound 3, half-maximal inhibitory concentration: 2.9 nM
Beside the measured number, compound 3's estimate is 1.0-fold (0.01 log units) above it; the measured number falls inside the stated range.
By their numbers in this assay, from the lowest: compounds 1, 2 and 3 (each within the scatter of the next).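

In this assay, hydroxymethyl in place of (ethylcarbamoyl)amino on a saturated chain carbon bound to an aromatic carbon gives a 1.4-fold higher number from compound 2 to compound 3 (0.14 log units; within the scatter), so the larger group can give way to a much smaller one with no difference that can be read. 4-(2-Hydroxyethyl)phenyl in place of 1,3-thiazol-2-yl on an aromatic carbon gives a 1.6-fold higher number from compound 1 to compound 3 (0.21 log units; within the scatter), so these two groups cannot be told apart either. Nothing available explains this result. Going by these compounds, whether an amine or a carboxylic acid in place of the hydroxymethyl, or a longer chain, would stay as close remains open.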